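Swapping ethylsulfanyl for isopropoxy on the five-membered ring

The source may hold more compounds than are shown below. What is called first, only, known or untested is meant among the compounds shown, and "the series" means these compounds.

Of the compounds shown here, two of this set have been measured in a functional assay on MV4-11 cells (Homo sapiens) for inhibition, read by resazurin assay, with a stated time of 72 h; on this read-out higher numbers stand for weaker inhibition of growth and lower numbers for stronger inhibition of growth. Compound 1 `CCSc1nc(C)c(-c2ccnc(Nc3ccc(OC)cc3OC)n2)s1` gives 32400 nM in this assay, the highest of the two numbers recorded. Compound 2 `COc1ccc(Nc2nccc(-c3cn(C(C)C)c4ccccc34)n2)c(OC)c1`, built on a different core, gives 3250 nM in this assay, a number a good deal lower than that of compound 1 and beyond the scatter; the two structures differ in more than one place, so the gap is noted without being tied to any single change.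

Compound 3 `COc1ccc(Nc2nccc(-c3sc(OC(C)C)nc3C)n2)c(OC)c1` has not yet been measured. It derives from compound 1 by one change: isopropoxy in place of ethylsulfanyl on an aromatic carbon. Among the compounds with values here, both the leaving and the entering group are uncharged, carry no hydrogen-bond donor and one hydrogen-bond acceptor, and no measured pair in the set shows what this exchange does. The expected step is a 1.3-fold lower number from compound 1 to compound 3 (0.11 log units; within the scatter), which is not clearly beyond the scatter in either direction. Compound 3 is accordingly estimated at 25000 nM in this assay, with a range of 8000 nM to 80000 nM.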

Compound 3, concentration for 50% growth inhibition: 8690 nM
Beside the measured number, compound 3's estimate is 2.9-fold (0.46 log units) above it, and the stated range covers the measured number.
By their numbers in this assay, from the lowest: compound 2; then compound 3; then compound 1.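

In this assay, the carbon of the five-membered aromatic ring next to the ring nitrogen and next to the ring sulfur now has its first measured exchange: isopropoxy in place of ethylsulfanyl gives a 3.7-fold lower number from compound 1 to compound 3 (0.57 log units; beyond the scatter), so the number at this position does move with the group it carries, modestly but beyond the scatter. The move comes with no change in hydrogen-bond donors, hydrogen-bond acceptors or net charge between the leaving and entering groups, while sulfur gives way to oxygen and the group goes from 3 heavy atoms to 4. Nothing at hand ties the step to any property of either group.

Within the data shown here, the single exchange leaves open whether the step follows the oxygen in place of the sulfur or the branched isopropyl chain in place of the ethyl chain, which ethoxy at the same place would help to separate. It also leaves open how an amine, a carboxylic acid or a longer alkoxy chain at this position would read, and whether the same exchange gives a similar step on another core.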